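Thiourea analogues and their cytotoxicity toward macrophage cells

The source may report more compounds than this note shows. Statements on the series, on what has been measured and on what is new or still open speak of the compounds shown alone.

Measured compounds:
compound 1, `OCCNC(=S)Nc1ccccc1`: 105000 nM
compound 2, `O=C(O)c1ccc(NC(=S)NCc2ccccc2)cc1O`: 197000 nM
compound 3, `O=C(NNC(=S)NCc1ccccc1)c1ccncc1`: 93200 nM

Three thioureas were tested in a toxicity assay on RAW264.7 cells (Mus musculus) for cytotoxicity, read by MTT assay, with a stated time of 24 h; on this read-out lower numbers stand for higher toxicity in this test and higher numbers for lower toxicity in this test. Compound 1 gives 105000 nM in this assay, compound 3 gives 93200 nM and compound 2 gives 197000 nM. The number of compound 1 sits closest to that of compound 3, and its gap to compound 2 also falls within the usual scatter of this kind of measurement, so the three compounds cannot be told apart on these data. Going by the values given here, none of the three shares a single-point change with another, so no step between measured compounds is available.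

The unmeasured compound 4, `OCCN(CCO)C(=S)Nc1ccccc1`, differs from compound 1 in one place: 2-hydroxyethyl in place of hydrogen on an amide-type nitrogen. Without a measured step of comparable kind, there is no observed basis for a shift in either direction in this assay, and the three measured values cluster closely. The step from compound 1 to compound 4 in this assay is therefore expected to be small, a 1.2-fold higher number from compound 1 to compound 4 (0.09 log units; within the scatter), and not beyond the scatter. For compound 4 the estimated value in this assay is 130000 nM, with a range from 60000 nM to 280000 nM.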

Compound 4, half-maximal cytotoxic concentration: >= 200000 nM
Compound 4: a limit, no number; the forecaster's own chance of this, stated with the estimate: 20%; middle value at least 1.5-fold (0.18 log units) from the limit.
By their numbers in this assay, from the lowest: compounds 3, 1 and 2 (each within the scatter of the next, the first and the last beyond it). At a limit, above all of these: compound 4.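

Setting 2-hydroxyethyl in place of hydrogen on an amide-type nitrogen gives the first one-place step in this set in this assay, an at least 1.9-fold higher number from compound 1 to compound 4 (0.27 log units; that floor lies within the scatter). Compound 4 stands at a limit and not at a number, so the step has a floor but no measured upper end: the limit of >= 200000 nM in this assay, at which 1 of the 4 values shown sits. This shows that this nitrogen, whose other neighbours are a saturated chain carbon and the thiocarbonyl carbon, can carry the added 2-hydroxyethyl group without the number falling, although a true rise is neither shown nor excluded while the floor lies within the scatter.

The compounds shown leave open whether a plain ethyl group, a longer chain such as 3-hydroxypropyl, or a chain ending in an amine or a carboxylic acid on this nitrogen would give a number rather than a limit. They also leave open whether the same change would read alike on the cores of compound 2 and compound 3.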